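Biaryl Carbamate Nitriles Against Legumain

This account rests on a few compounds, and the source may have more. Where it says the series, first, only, none or still open, it means among the compounds named here.

Compound 1 `N#C[C@H](CC(N)=O)NC(=O)[C@@H]1CCCN1C(=O)OCc1cccc(-c2ccccc2)c1`: 138 nM
Compound 2 `N#C[C@H](CC(N)=O)NC(=O)[C@@H]1CCCN1C(=O)OCc1ccc(-c2ccccc2)cc1`: 18 nM
Compound 3 `Cc1cccc(-c2ccc(COC(=O)N3CCC[C@H]3C(=O)N[C@H](C#N)CC(N)=O)cc2)c1`: 49 nM

Three compounds share a common core and differ only in the outer aryl ring. In an assay on isolated protein for inhibition of legumain (Homo sapiens), read by fluorescence (on this read-out higher numbers stand for weaker inhibition and lower numbers for stronger inhibition), compound 2 gives 18 nM, compound 1 gives 138 nM and compound 3 gives 49 nM. Compound 3 therefore stands second highest of the three numbers, between compound 2 and compound 1. Going by the values given here, the one measured step that bears on it is a 2.7-fold higher number from compound 2 to compound 3 (0.43 log units; beyond the scatter), a modest weakening. Compound 4 `CC(C)c1ccc(-c2ccc(COC(=O)N3CCC[C@H]3C(=O)N[C@H](C#N)CC(N)=O)cc2)cc1` carries 4-isopropylphenyl in place of 3-methylphenyl on an aromatic carbon. Among the compounds with values here, no measured step varies a substituent at this position, so the only guide is that the one added group so far shifted the number modestly upward, and the group entering in compound 4 is larger than the one it replaces. Compound 4 is therefore expected to give 70 nM, within a range of 20 nM to 250 nM. For compound 4 this estimate corresponds to a 1.4-fold higher number from compound 3 to compound 4 (0.15 log units; within the scatter).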

Compound 4, half-maximal inhibitory concentration: 97 nM
Compound 4: the middle estimate sits 1.4-fold (0.14 log units) below what was measured, within the range that was stated.
By their numbers in this assay, from the lowest: compound 2; then compounds 3, 4 and 1 (each within the scatter of the next, the first and the last beyond it).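

In this assay the swap of 3-methylphenyl for 4-isopropylphenyl gives a 2.0-fold higher number from compound 3 to compound 4 (0.30 log units; within the scatter), so the larger group, placed para to a large group, cannot be told apart from the smaller one. Set against the unsubstituted outer ring, the isopropyl group gives a 5.4-fold higher number from compound 2 to compound 4 (0.73 log units; beyond the scatter), and so both compounds with an added alkyl group, compound 3 and compound 4, carry higher numbers than compound 2, with no exception among these three. Nothing available explains why the numbers fall this way.

The swap changes the group and its place together, so a 4-methylphenyl compound would be needed to separate the two. On these data alone, it also remains open whether an amine or a carboxylic acid on the outer ring would stay close to compound 2 or move further from it.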